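The source may report more compounds than this note shows. Statements on the series, on what has been measured and on what is new or still open speak of the compounds shown alone.

Within the data shown here, in a functional assay on NCI-H460 cells (Homo sapiens) for cytotoxicity (a lower number here means a stronger inhibitor, a higher number a weaker inhibitor), compound 3 `O=C(CCCCCCC(=O)Nc1nc2ccc([N+](=O)[O-])cc2s1)NO` gives 1.9 ug/mL, the lowest number so far. Compound 2 `Cc1ccc2nc(NC(=O)CCCCC(=O)NO)sc2c1` gives 11 ug/mL. Compound 1 `CS(=O)(=O)c1ccc2nc(NC(=O)CCCCC(=O)NO)sc2c1` gives > 30 ug/mL, which is a limit and not a number. Compound 4 `O=C(CCCCC(=O)Nc1nc2ccc([N+](=O)[O-])cc2s1)NO` differs from compound 3 by hydroxycarbamoyl in place of 2-(hydroxycarbamoyl)ethyl on a saturated chain carbon, four bonds along the chain from a carbonyl carbon. Among the measured compounds shown here, no measured step makes this change. For the measured compounds named here, the only step, an at least 2.7-fold lower number from compound 1 to compound 2 (0.43 log units; beyond the scatter), is methyl in place of methylsulfonyl on an aromatic carbon, and it bears only indirectly, on the chain that compound 4 shares. A moderate rise in this assay is expected, given that compound 2 with this chain stands at 11 ug/mL. The estimated step is a 2.6-fold higher number from compound 3 to compound 4 (0.42 log units; beyond the scatter). For compound 4, the expected value is 5 ug/mL, with an estimated range of 1.9 ug/mL to 15 ug/mL.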

Compound 4, half-maximal inhibitory concentration: > 30 ug/mL
Compound 4: only a limit was reported (the forecaster's own chance of this, stated with the estimate: 7%); middle value at least 6.0-fold (0.77 log units) from the limit.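

With nitro held fixed, hydroxycarbamoyl in place of 2-(hydroxycarbamoyl)ethyl gives an at least 15-fold higher number from compound 3 to compound 4 (1.19 log units; beyond the scatter), so in this assay the chain at this position weighs heavily. With the chain held fixed, nitro in place of methyl gives an at least 2.7-fold higher number from compound 2 to compound 4 (0.43 log units; beyond the scatter), so nitro alone does not secure a low number. Compound 4 gives only a limit, not a number, and its step from compound 1 cannot be read: the limit of > 30 ug/mL in this assay, at which 2 of the 4 values shown sit.

Still open, going by these compounds, is whether a chain longer than 4-(hydroxycarbamoyl)butyl lowers the number further. Also open, on these data alone, is how methyl or an amine in place of nitro behaves on the chain of compound 3.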